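This account rests on a few compounds, and the source may have more. Where it says the series, first, only, none or still open, it means among the compounds named here.

In an assay for inhibition of Amine oxidase [flavin-containing] A (Rattus norvegicus) (on this read-out lower numbers stand for stronger inhibition and higher numbers for weaker inhibition), compound 3 `COc1cccc(COc2ccc(C3=NN(CCC#N)C(=O)CO3)cc2)c1` gives 32000 nM, the highest of the three numbers recorded so far. Compound 1 `N#CCCn1nc(-c2ccc(OCc3cccc(Cl)c3)cc2)oc1=S` gives 11000 nM, and compound 2 `N#CCCn1nc(-c2ccc(OCc3ccc([N+](=O)[O-])cc3)cc2)oc1=S` gives 2600 nM; compound 3 therefore lies beyond the scatter from both, nearest to compound 1 and furthest from compound 2. Compound 4 `N#CCCN1N=C(c2ccc(OCc3ccc([N+](=O)[O-])cc3)cc2)OCC1=O` has not yet been measured; it differs from compound 3 by 4-nitrophenyl in place of 3-methoxyphenyl on a saturated chain carbon bound to an oxygen on an aromatic ring, the core of compound 3 staying unchanged. Among the measured compounds shown here, the single measured step that bears on this exchange is on the core of compound 1: a 4.2-fold lower number from compound 1 to compound 2 (0.63 log units; beyond the scatter). For the measured compounds named here, that step starts from a 3-chlorophenyl rather than a 3-methoxyphenyl, and it is observed on a different core, so it is only a partial guide; no measured pair shows what the move from 3-methoxyphenyl to 3-chlorophenyl does in this assay. Going by the values given here, because the only comparable step was a 4.2-fold lower number from compound 1 to compound 2 (0.63 log units; beyond the scatter), a lowering of similar size, beyond the scatter, is expected for compound 4, which would place it between compound 1 and compound 2. The step expected in this assay is a 3.6-fold lower number from compound 3 to compound 4 (0.55 log units; beyond the scatter). Compound 4 is estimated at 9000 nM, with a range from 3000 nM to 30000 nM.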

Compound 4, half-maximal inhibitory concentration: 2000 nM
Estimate against measurement, compound 4: 4.5-fold (0.65 log units) above; measured number outside the range, below it.
By their numbers in this assay, from the lowest: compounds 4 and 2 (each within the scatter of the next); then compound 1; then compound 3.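

On the core of compound 3, 4-nitrophenyl in place of 3-methoxyphenyl on a saturated chain carbon bound to an oxygen on an aromatic ring gives, in this assay, a 16-fold lower number from compound 3 to compound 4 (1.20 log units; beyond the scatter), a large step. The earlier step on the other core, a 4.2-fold lower number from compound 1 to compound 2 (0.63 log units; beyond the scatter), shares the entering group but starts from 3-chlorophenyl, so the two steps differ in both the leaving group and the core, and their sizes cannot be set directly against each other. The new result does show that 4-nitrophenyl goes with a low number on both cores: compound 2 gives 2600 nM and compound 4 gives 2000 nM, two values within the scatter of each other, so in this pair the change of core leaves no readable difference.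

What the compounds shown leave open is how much of the step depends on the entering 4-nitrophenyl and how much on the departing 3-methoxyphenyl, and an unsubstituted phenyl, a 3-nitrophenyl or a 4-aminophenyl at this place would help to separate the two. No information at hand accounts for the size of the step.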